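Compound 3 to Compound 4: Phenyl in Place of Methyl

A few compounds are considered here, and "the series" means these few. Any claim that something is new, unique, unknown or untested is made for them only; others in the source may bear on it.

Of the compounds shown here, three sharing one core have been tested in a functional assay on MCF7 cells (Homo sapiens) for antiproliferative activity, read by MTT assay, with a stated time of 24 h; on this read-out higher numbers stand for weaker inhibition and lower numbers for stronger inhibition. Compound 1 (`CCCCc1oc2ccccc2c1C(=O)c1cc(I)c(OCCCN2CCCCC2)c(I)c1`), carrying piperidin-1-yl, gives 37900 nM. Compound 2 (`CCCCc1oc2ccccc2c1C(=O)c1cc(I)c(OCCCN2CCN(C)CC2)c(I)c1`), carrying 4-methylpiperazin-1-yl, gives 5370 nM. Compound 3 (`CCCCc1oc2ccccc2c1C(=O)c1cc(I)c(OCCCN2CCN(CC)CC2)c(I)c1`), carrying 4-ethylpiperazin-1-yl, gives 39500 nM, which places it level with compound 1 and at a clearly higher number than compound 2.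

Compound 4 (`CCCCc1oc2ccccc2c1C(=O)c1cc(I)c(OCCCN2CCN(Cc3ccccc3)CC2)c(I)c1`) has not yet been measured. Its structure departs from that of compound 3 by phenyl in place of methyl on a saturated chain carbon bound to an amine nitrogen in a ring, which also reads as ethyl to benzyl.

The nearest evidence is the step at this same place, a 7.4-fold higher number from compound 2 to compound 3 (0.87 log units; beyond the scatter), a modest change from adding only methyl in place of hydrogen. The other two steps are a 7.1-fold lower number from compound 1 to compound 2 (0.85 log units; beyond the scatter) and a 1.0-fold higher number from compound 1 to compound 3 (0.02 log units; within the scatter), and only the first of these lies beyond the scatter. None of the three brings in a ring, so they show that this region can matter but do not fix a direction. A step within the scatter is therefore expected in this assay, with a slight lean towards a lower number. The expected change is a 1.6-fold lower number from compound 3 to compound 4 (0.20 log units; within the scatter). For compound 4 the estimated value is 25000 nM, within an expected range of 6000 nM to 70000 nM.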

Compound 4, half-maximal inhibitory concentration: 28700 nM
Estimate against measurement, compound 4: 1.1-fold (0.06 log units) below; the measured number falls inside the stated range.
By their numbers in this assay, from the lowest: compound 2; then compounds 4, 1 and 3 (each within the scatter of the next).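

In this assay, within the data shown here, benzyl in place of ethyl gives a 1.4-fold lower number from compound 3 to compound 4 (0.14 log units; within the scatter), so bringing in one six-membered aromatic ring of carbon only, which none of the earlier compounds carried at this place, leaves the reading within the scatter. The other new step, a 5.3-fold higher number from compound 2 to compound 4 (0.73 log units; beyond the scatter), shows that compound 2 stays apart from the benzyl compound as it does from the ethyl compound, so among the groups shown here at this place, methyl alone goes with the clearly lower number, and the further atoms of benzyl add nothing beyond the scatter to what ethyl already shows. Nothing in the material at hand bears on what lies behind these readings.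

Going by these compounds, what a plain hydrogen on that ring nitrogen, a propyl chain or a phenylethyl group would give remains open, so it cannot yet be said whether the reading of compound 2 is a narrow exception or part of a wider trend. Also open, on these data alone, is whether a benzyl ring carrying a hydroxyl or an amine would stay level with compound 4 in this assay.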